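Acid to primary amide on the chain of compound 3

The source may hold more compounds than are shown below. What is called first, only, known or untested is meant among the compounds shown, and "the series" means these compounds.

Three compounds have numbers in an in vitro assay on BHK cells for inhibition of Glucagon receptor (Homo sapiens); a lower number here means a stronger inhibitor, a higher number a weaker inhibitor. Compound 1 `CCCCC(CC)N(Cc1ccc(C(=O)NCCC(=O)O)cc1)C(=O)Nc1ccc(OC(F)(F)F)cc1` gives 141 nM, and compound 2 `O=C(O)CCNC(=O)c1ccc(CN(C(=O)Nc2cc(Cl)cc(Cl)c2)c2ccc(C3=CCCCC3)cc2)cc1` gives 27 nM. Compound 3 `CC(C)(C)C1CCC(N(Cc2ccc(C(=O)NCCCC(=O)O)cc2)C(=O)Nc2ccc(OC(F)(F)F)cc2)CC1` returns only a limit, > 10000 nM, and so stands at the weak end of the three; this is the limit of > 10000 nM in this assay, at which 1 of the 3 values shown sits. Compound 4 `CC(C)(C)C1CCC(N(Cc2ccc(C(=O)NCCC(N)=O)cc2)C(=O)Nc2ccc(OC(F)(F)F)cc2)CC1` is the next member: carbamoyl in place of carboxymethyl on a saturated chain carbon, two bonds along the chain from an amide-type nitrogen. No measured pair differs in only this place, so nothing shown gives the size of such a change. With compound 3 at a limit, the expected step that the limit leaves unreadable from compound 3 to compound 4 is none beyond the scatter, and compound 4 is expected to sit at or near that limit as well. Compound 4 is estimated at 12000 nM, between 3000 nM and 50000 nM.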

Compound 4, half-maximal inhibitory concentration: > 10000 nM
Compound 4 gave a limit, no number; the forecaster's own chance of this, stated with the estimate: 70%; the middle value is on the limit's open side.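

Compound 3 and compound 4 both return limits, not numbers, and no step can be read between them: the limit of > 10000 nM in this assay, at which 2 of the 4 values shown sit.

The compounds shown leave open the size of the change from carboxymethyl to carbamoyl at this place on the chain.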